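The source may hold more compounds than are shown below. What is called first, only, known or untested is meant among the compounds shown, and "the series" means these compounds.

Compound 3 `CCN(CC)C(=O)Cc1c(-c2ccc(OCc3ccccc3)cc2)nn2c(C)cc(C)nc12` gives 0.99 nM in an assay on isolated protein (kidney, strain Wistar) for displacement of a labelled ligand from Translocator protein (Rattus norvegicus), read by scintillation counting, with a stated time of 90 min; a lower number here means a stronger inhibitor, a higher number a weaker inhibitor. Among the three compounds measured, compound 3 has the lowest number. Compound 1 `CCN(CC)C(=O)Cc1c(-c2ccc(OC3CCCC3)cc2)nn2c(C)cc(C)nc12` gives 1.5 nM, and the step of a 1.5-fold lower number from compound 1 to compound 3 (0.18 log units; within the scatter) stays within the scatter, so these two cannot be ordered. Compound 2 `CCN(CC)C(=O)Cc1c(-c2ccc(OCC3CCCC3)cc2)nn2c(C)cc(C)nc12` gives 2.1 nM, and the step of a 2.1-fold lower number from compound 2 to compound 3 (0.33 log units; beyond the scatter) is a modest one beyond the scatter.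

Compound 4 `CCN(CC)C(=O)Cc1c(-c2ccc(OCc3ccccc3F)cc2)nn2c(C)cc(C)nc12` differs from compound 3 by fluoro in place of hydrogen on an aromatic carbon, so that the benzyl group on the oxygen becomes a 2-fluorobenzyl group. Within the data shown here, none of the measured steps adds a single atom to an aromatic ring; the steps of a 1.4-fold higher number from compound 1 to compound 2 (0.15 log units; within the scatter) and a 1.5-fold lower number from compound 1 to compound 3 (0.18 log units; within the scatter) each exchanged the whole group on the oxygen and stayed within the scatter, and only the step of a 2.1-fold lower number from compound 2 to compound 3 (0.33 log units; beyond the scatter) went beyond it, modestly. With the group on the oxygen left almost intact, no step beyond the scatter is expected here, and the expected step is a 1.0-fold higher number from compound 3 to compound 4 (0.00 log units; within the scatter). Compound 4 is therefore estimated at 1 nM, with a range from 0.45 nM to 2.2 nM.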

Compound 4, inhibition constant: 0.31 nM
Compound 4: the middle estimate sits 3.2-fold (0.51 log units) above what was measured, and the stated range ends above it.
By their numbers in this assay, from the lowest: compound 4; then compounds 3, 1 and 2 (each within the scatter of the next, the first and the last beyond it).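

A single fluoro in place of hydrogen, on an aromatic carbon ortho to a large group, gives a 3.2-fold lower number from compound 3 to compound 4 (0.50 log units; beyond the scatter) in this assay. One added heavy atom thus moves the number beyond the scatter, whereas two of the three earlier exchanges of the whole group on the oxygen stayed within it. The 2-fluorobenzyl group also sets compound 4 clearly apart from the compounds with saturated rings, with a 4.8-fold lower number from compound 1 to compound 4 (0.68 log units; beyond the scatter) and a 6.8-fold lower number from compound 2 to compound 4 (0.83 log units; beyond the scatter), and no measurement offered here explains why this one atom has such an effect.

Going by these compounds, it remains open whether fluoro on another carbon of the same ring would give a similar step. On these data alone, it is equally open whether chloro, methyl or methoxy on this same carbon would do so.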